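A few compounds are considered here, and "the series" means these few. Any claim that something is new, unique, unknown or untested is made for them only; others in the source may bear on it.

Measured so far:
compound 1 `CNC(=O)COc1cc(=O)oc2cc(OCc3cccc(Cl)c3)ccc12` — 33.9 nM
compound 2 `O=c1cc(CCl)c2ccc(OCc3cccc(Br)c3)cc2o1` — 209 nM

In an assay on isolated protein (strain Sprague-Dawley) for inhibition of Amine oxidase [flavin-containing] B (Rattus norvegicus), read by spectrophotometry, with a stated time of 5 min (on this read-out lower numbers stand for stronger inhibition and higher numbers for weaker inhibition), compound 1 gives 33.9 nM, the lowest of the two numbers and well apart from compound 2, which gives 209 nM. Compound 3 `O=Cc1cc(=O)oc2cc(OCc3cccc(Cl)c3)ccc12` is not yet measured. It differs from compound 1 in one place: formyl in place of (methylcarbamoyl)methoxy on an aromatic carbon. Among the compounds with values here, no measured pair shows this same change, so the direction rests only on the two numbers known. Since compound 1 holds the lower number, this step is expected to weaken inhibition, as a 4.4-fold higher number from compound 1 to compound 3 (0.65 log units; beyond the scatter), beyond the scatter. Compound 3 is therefore expected to give about 150 nM in this assay, between 45 nM and 500 nM.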

Compound 3, half-maximal inhibitory concentration: 52.5 nM
Compound 3: the middle estimate sits 2.9-fold (0.46 log units) above what was measured, within the range that was stated.
By their numbers in this assay, from the lowest: compounds 1 and 3 (each within the scatter of the next); then compound 2.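

Formyl in place of (methylcarbamoyl)methoxy on this aromatic carbon is a 1.5-fold higher number from compound 1 to compound 3 (0.19 log units; within the scatter) in this assay, so the two groups cannot be told apart here. The larger group, with 6 heavy atoms and its hydrogen-bond donor, is therefore not needed at this position for a low number: formyl, with 2 heavy atoms and no donor, reads the same. Nothing shown here explains this match. Still open, from the compounds shown here alone, is whether an amine, a carboxylic acid or a longer chain on this carbon would also keep the number low.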